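Benzyl in place of isobutyl: the expected acid dissociation

The compounds below may be only part of what the source reports. "The series", "measured", "known", "first", "only" and "open" are said of these compounds alone.

Compound 3 `COc1ccc(F)cc1CNCCCNc1ccnc2cc(CC(C)C)ccc12` gives 9.47 in a physicochemical assay for acid dissociation. It stands level with compound 1 `CC(C)Cc1ccc2c(NCCCNCc3ccco3)ccnc2c1`, which gives 9.47, and is a number 0.19 log units higher from compound 2 to compound 3 (within the scatter); compound 2 `COc1cccc(Oc2ccc3c(NCCCNCc4cc(F)ccc4OC)ccnc3c2)c1` gives 9.28. Compound 4 `COc1ccc(F)cc1CNCCCNc1ccnc2cc(Cc3ccccc3)ccc12` differs from compound 3 in one place: phenyl in place of isopropyl on a saturated chain carbon bound to an aromatic carbon. The step that bears on this is the earlier exchange on that same aromatic carbon of the shared core, which stayed within the scatter; the exchange of furan-2-yl for 5-fluoro-2-methoxyphenyl, no change at the digits printed from compound 1 to compound 3 (within the scatter), also left the number unchanged. Compound 4 is therefore expected to stay within the scatter of compound 3, a step of a number 0.05 log units lower from compound 3 to compound 4 (within the scatter). The estimate for compound 4 is 9.42, between 9.1 and 9.75.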

Compound 4, acid dissociation constant: 9.47
For compound 4 the middle estimate is 0.05 log units below the measured one; measured number inside the range.
By their numbers in this assay, from the lowest: compounds 2, 1, 3 and 4 (each within the scatter of the next).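

Phenyl in place of isopropyl on a saturated chain carbon bound to an aromatic carbon leaves this assay where it was (no change at the digits printed from compound 3 to compound 4 (within the scatter)), so this position also accepts a six-membered aromatic ring at the end of its chain. A second single exchange likewise stays within the scatter (a number 0.19 log units higher from compound 2 to compound 4 (within the scatter)), which puts benzyl, isobutyl and 3-methoxyphenoxy on level terms here. No measurement shown gives a reason for this. On these data alone, whether an amine or a carboxylic acid on this same aromatic carbon would also leave the number level remains open.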